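One Stereocentre Inverted in an Antiproliferative Series

A few compounds are considered here, and "the series" means these few. Any claim that something is new, unique, unknown or untested is made for them only; others in the source may bear on it.

In a functional assay (HSMC cells, Homo sapiens) for antiproliferative activity, with a stated time of 72 h (on this read-out higher numbers stand for weaker inhibition and lower numbers for stronger inhibition), compound 3 `COC(=O)CNC(=O)c1ccc(OC[C@H]2COc3ccccc3O2)cc1-c1ccccc1OC` gives 71000 nM, which places it in the middle of the three measured compounds. Compound 1 `COC(=O)[C@H](CCSC)NC(=O)c1ccc(OC[C@@H]2COc3ccccc3O2)cc1-c1ccccc1OC` gives a higher number, 204000 nM, and compound 2 `COC(=O)CNC(=O)c1ccc(OC[C@@H]2COc3ccccc3O2)cc1-c1ccccc1C` gives a much lower one, 700 nM. Both gaps to compound 3 lie beyond the usual scatter.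

Compound 4 `COC(=O)CNC(=O)c1ccc(OC[C@@H]2COc3ccccc3O2)cc1-c1ccccc1OC` has not yet been measured. It differs from compound 3 in one respect only: the two compounds have the same atoms and bonds and differ only in configuration as drawn: 1 of 1 stereo elements differ; a stereocentre at a saturated ring carbon is drawn S in compound 3 and R in compound 4. The two compounds have the same atoms and bonds, and a stereocentre at a saturated ring carbon is drawn S in compound 3 and R in compound 4.

Going by the values given here, no measured pair isolates this inversion, so its size in this assay cannot be read directly. The R drawing is also found in compound 2, whose 700 nM suggests a move toward stronger inhibition. Compound 1 carries the same drawing and goes against that suggestion with 204000 nM, so the expectation remains loose. The expected change is a 12-fold lower number from compound 3 to compound 4 (1.07 log units; beyond the scatter), an estimated step toward stronger inhibition and beyond the scatter. For compound 4 the estimated value is 6000 nM, with an expected range from 700 nM to 60000 nM.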

Compound 4, half-maximal inhibitory concentration: 35000 nM
For compound 4 the middle estimate is 5.8-fold (0.77 log units) below the measured one, and the stated range covers the measured number.
By their numbers in this assay, from the lowest: compound 2; then compound 4; then compound 3; then compound 1.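

In this assay, the inversion at the saturated ring carbon now has a measured size of its own, a 2.0-fold lower number from compound 3 to compound 4 (0.31 log units; beyond the scatter), and this step can be assigned to that stereocentre alone for one reason: the fact that compounds 3 and 4 differ only in the configuration as drawn

The R drawing therefore does not by itself bring the low number seen earlier, as the larger step on this core comes with methoxy in place of methyl on an aromatic carbon, a 50-fold higher number from compound 2 to compound 4 (1.70 log units; beyond the scatter). With the R drawing held constant, hydrogen in place of 2-(methylsulfanyl)ethyl on a saturated chain carbon bound to an amide-type nitrogen and a carbonyl carbon gives a further step, a 5.8-fold lower number from compound 1 to compound 4 (0.77 log units; beyond the scatter).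

Going by these compounds, whether the inversion keeps this size when methyl stands in place of methoxy, or when the 2-(methylsulfanyl)ethyl chain is present, remains open. Also open, on these data alone, is how either drawing of the stereocentre would fare with a carboxylic acid in place of the methyl ester.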